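The compounds below may be only part of what the source reports. "The series", "measured", "known", "first", "only" and "open" are said of these compounds alone.

Measured compounds:
- compound 1 `Cc1noc(-c2cc3cc(Cl)ccc3[nH]2)n1`, which in a functional assay on MCF7 cells (Homo sapiens) for antiproliferative activity, read by WST assay, with a stated time of 72 h (on this read-out higher numbers stand for weaker inhibition and lower numbers for stronger inhibition), gives 34400 nM
- compound 2 `Oc1ccc2[nH]c(-c3nc(-c4ccccc4)no3)cc2c1`, which in this assay gives 26000 nM

Compound 2 has the lower of the two numbers shown, yet its gap to compound 1 lies within the scatter of repeated measurements, so the two cannot be told apart on these data. Both numbers describe weak inhibition of cell growth.

Compound 3 `Clc1ccc2[nH]c(-c3nc(-c4ccccc4)no3)cc2c1` is not yet measured in this assay. It differs from compound 2 in one place: chloro in place of hydroxy on an aromatic carbon. Among the compounds with values here, no step between two measured compounds isolates this exchange, so no measured step can guide the expectation. Compound 1 carries the same chloro group on its core, with a different substituent on the oxadiazole, and its number is close to that of compound 2.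

The step from compound 2 to compound 3 is therefore expected to be small, a 1.0-fold lower number from compound 2 to compound 3 (0.02 log units; within the scatter), without a clear direction beyond the scatter. For compound 3 in this assay the estimate is 25000 nM, within a range from 8000 nM to 70000 nM.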

Compound 3, half-maximal inhibitory concentration: 29100 nM
Estimate against measurement, compound 3: 1.2-fold (0.07 log units) below; low and high end bracket the measured number.
By their numbers in this assay, from the lowest: compounds 2, 3 and 1 (each within the scatter of the next).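

In this assay, the exchange of hydroxy for chloro on the aromatic carbon of the shared core now has a measured step of its own (a 1.1-fold higher number from compound 2 to compound 3 (0.05 log units; within the scatter)), so at this position the change cannot be read as making any difference. The second step, phenyl in place of methyl with chloro held constant (a 1.2-fold lower number from compound 1 to compound 3 (0.07 log units; within the scatter)), also lies within the scatter, so neither of the two places varied here has yet separated a pair of compounds. No measurement shown here accounts for how close these numbers lie.

The compounds shown leave open whether any group at this position can move the number beyond the scatter, for instance an amine or a carboxylic acid in place of chloro. They also leave open whether a longer chain in place of phenyl would do so.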